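Adding a chloro to the anilino ring: compound 3 to compound 4

The compounds below may be only part of what the source reports. "The series", "measured", "known", "first", "only" and "open" are said of these compounds alone.

Measured compounds:
- compound 1 `N#Cc1c(Cl)nc(SCC(=O)Nn2c(COc3ccc(Cl)cc3Cl)nc3ccccc3c2=O)nc1-c1ccc(Cl)cc1`: 68.4%
- compound 2 `N#Cc1c(Nc2ccc(Cl)cc2)nc(SCC(=O)Nn2c(COc3ccc(Cl)cc3Cl)nc3ccccc3c2=O)nc1-c1ccccc1`: 57.9%
- compound 3 `N#Cc1c(Nc2ccccc2)nc(SCC(=O)Nn2c(COc3ccc(Cl)cc3Cl)nc3ccccc3c2=O)nc1-c1ccc(Cl)cc1`: 50.9%

In a functional assay on the whole organism (strain albino) for inhibition, with Rattus norvegicus as the target, read by paw edema, with stated times of 1 h and 2 h, at a dose of 100 mg/kg by the oral route (on this read-out higher numbers stand for more inhibition at the one dose given (going by the name of the read-out) and lower numbers for less inhibition), compound 3 gives 50.9%. This is the lowest of the three numbers. Compound 2 gives 57.9%, which lies within the scatter of compound 3, so the two cannot be told apart. Going by the values given here, compound 1 gives 68.4%, and the only single-point step among the measured compounds, a number 17.5 percentage points lower from compound 1 to compound 3 (beyond the scatter), is a modest drop that goes beyond the scatter.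

Compound 4 `N#Cc1c(Nc2ccc(Cl)cc2)nc(SCC(=O)Nn2c(COc3ccc(Cl)cc3Cl)nc3ccccc3c2=O)nc1-c1ccc(Cl)cc1` has not been measured. It differs from compound 3 in one place: chloro in place of hydrogen on an aromatic carbon. Among the compounds with values here, no measured pair shows exactly this change, so no step bears on it directly. Compound 2, which carries the same (4-chlorophenyl)amino group, sits within the scatter of compound 3, which suggests no strong effect.

Compound 4 is therefore expected to stay close to compound 3, with a step of a number 5.1 percentage points higher from compound 3 to compound 4 (within the scatter) that is estimated to lie within the scatter. The estimate for compound 4 in this assay is 56%, with a range from 44% to 68%.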

Compound 4, a percentage reported as inhibition, in the whole organism at one dose (the size of the read-out at that dose, not a potency): 61.4%
Compound 4: middle estimate off by 5.4 percentage points, on the low side; the range from low to high includes it.
By their numbers in this assay, from the lowest: compounds 3, 2, 4 and 1 (each within the scatter of the next, the first and the last beyond it).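

In this assay, a chloro on the anilino ring, para to a large group, gives a number 10.5 percentage points higher from compound 3 to compound 4 (beyond the scatter), so this position on that ring can change the read-out by more than the scatter. The earlier compounds shown here showed that anilino in place of the chloro on the core costs inhibition, a number 17.5 percentage points lower from compound 1 to compound 3 (beyond the scatter), but with the (4-chlorophenyl)amino group that cost can no longer be told from scatter: a number 7 percentage points lower from compound 1 to compound 4 (within the scatter). The same swap of hydrogen for chloro on the other phenyl ring, which carries the second chloro of the pair, gives a number 3.5 percentage points higher from compound 2 to compound 4 (within the scatter), so at this one dose a chloro there has no readable effect once the anilino ring already carries its chloro.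

Nothing at hand explains why the chloro on the anilino ring moves the number. As far as these compounds go, it remains open whether a fluoro, a methyl or a methoxy at the same place would do what the chloro does, and whether an amine such as morpholine or piperidine could take the place of the anilino group on the core.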